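Replacing a Bromophenyl Group with a Methylphenyl Group

A few compounds are considered here, and "the series" means these few. Any claim that something is new, unique, unknown or untested is made for them only; others in the source may bear on it.

Of the compounds shown here, three built on one shared core have been tested in an assay on CHO cells for displacement of a labelled ligand from adenosine receptor A3 (Homo sapiens), read by scintillation counting, with a stated time of 45 min, tested at 1 uM, in the presence of a further agent that is not named here; on this read-out higher numbers stand for more inhibition at the one concentration tested (going by the name of the read-out) and lower numbers for less inhibition. Compound 1 `CCCn1c(=O)[nH]c2nc(-c3ccc(S(=O)(=O)N4CCN(c5ccc(Cl)cc5F)CC4)cc3)[nH]c2c1=O` gives 14%. Compound 2 `CCCn1c(=O)[nH]c2nc(-c3ccc(S(=O)(=O)N4CCN(c5ccccc5Br)CC4)cc3)[nH]c2c1=O` gives 20%. Compound 3 `CCCn1c(=O)[nH]c2nc(-c3ccc(S(=O)(=O)N4CCN(c5cccc(Br)c5)CC4)cc3)[nH]c2c1=O` gives 27%, the highest of the three numbers, although its distance from compound 2 lies within the scatter, so only its distance from compound 1 counts as a real difference.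

The step of a number 13 percentage points higher from compound 1 to compound 3 (beyond the scatter) and the step of a number 7 percentage points higher from compound 2 to compound 3 (within the scatter) describe how the phenyl groups on the amine nitrogen in the ring differ among the measured compounds. Compound 4 `CCCn1c(=O)[nH]c2nc(-c3ccc(S(=O)(=O)N4CCN(c5ccc(C)cc5)CC4)cc3)[nH]c2c1=O` brings a change of another kind: 4-methylphenyl in place of 3-bromophenyl on an amine nitrogen in a ring. Within the data shown here, no measured step exchanges a bromine for a methyl group, so nothing among the three compounds speaks directly to this change. All three numbers are low and close together, so compound 4 is expected to remain in the same region, with a step of a number 9 percentage points lower from compound 3 to compound 4 (within the scatter) expected to stay within the scatter. Compound 4 is therefore estimated at 18%, with a range from 5% to 32%.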

Compound 4, a percentage reported as inhibition, at one concentration (the size of the read-out at that concentration, not a potency): 25%
Compound 4: middle estimate off by 7 percentage points, on the low side; measured number inside the range.
By their numbers in this assay, from the lowest: compounds 1, 2, 4 and 3 (each within the scatter of the next, the first and the last beyond it).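

Putting 4-methylphenyl in place of 3-bromophenyl gives a number 2 percentage points lower from compound 3 to compound 4 (within the scatter), so in this assay a phenyl group at this position can carry a methyl group and no halogen and still stay level with compound 3, which the three halogen-bearing earlier compounds could not show. The same change gives a number 5 percentage points higher from compound 2 to compound 4 (within the scatter), while replacing 4-chloro-2-fluorophenyl gives a number 11 percentage points higher from compound 1 to compound 4 (beyond the scatter), so compound 4 joins compound 3 in standing apart from compound 1. Nothing available offers an explanation for these numbers.

Compound 4 swaps the bromine for a methyl group and also moves the substituent, so 3-methylphenyl or 4-bromophenyl would be needed to separate those two changes. As far as these compounds go, it also remains open how this position would respond to a polar group on the phenyl ring, such as an amine or a carboxylic acid.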